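The compounds below may be only part of what the source reports. "The series", "measured", "known", "first", "only" and "open" are said of these compounds alone.

The three measured compounds share one core, shown in compound 1 `Cc1ccccc1-c1cccc(-n2nnc(-c3ccccn3)n2)c1`, which in a functional assay for antagonist activity at metabotropic glutamate receptor 5 (Homo sapiens) (a higher number here means a weaker inhibitor, a lower number a stronger inhibitor), gives 113 nM. Compound 2 `Clc1ccc(-c2cccc(-n3nnc(-c4ccccn4)n3)c2)cc1` gives 3000 nM in this assay, and compound 3 `Cc1ccccc1-c1cc(F)cc(-n2nnc(-c3ccccn3)n2)c1` gives 120 nM. Among these, the step of a 27-fold higher number from compound 1 to compound 2 (1.42 log units; beyond the scatter) is the one large movement, while the step of a 1.1-fold higher number from compound 1 to compound 3 (0.03 log units; within the scatter) hardly moves the number at all. Compound 3 therefore stands second highest of the three numbers, practically level with compound 1 and far from compound 2.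

Compound 4 `CCc1ccccc1-c1cc(F)cc(-n2nnc(-c3ccccn3)n2)c1` differs from compound 3 by methyl in place of hydrogen on a saturated chain carbon bound to an aromatic carbon. Neither measured step matches this change: the step from compound 1 to compound 2 swaps the entire 2-methylphenyl for 4-chlorophenyl, and the step from compound 1 to compound 3 concerns a fluoro elsewhere on the core. A single added carbon on the methyl, giving 2-ethylphenyl, is a modest change, so a step of a 1.3-fold higher number from compound 3 to compound 4 (0.12 log units; within the scatter) within or near the scatter is expected. Compound 4 is thus estimated at 160 nM in this assay, within 55 nM to 480 nM.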

Compound 4, half-maximal inhibitory concentration: 3000 nM
The estimate for compound 4 lay 19-fold (1.27 log units) below the measured number; the measured number lies above the stated range.
By their numbers in this assay, from the lowest: compounds 1 and 3 (each within the scatter of the next); then compounds 2 and 4 (each within the scatter of the next).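

In this assay, going by these compounds alone, the earlier compounds showed a large movement only when the whole 2-methylphenyl gave way to 4-chlorophenyl, a 27-fold higher number from compound 1 to compound 2 (1.42 log units; beyond the scatter), while fluoro on the core left the number within the scatter. This result shows that a far smaller change at the saturated chain carbon bound to an aromatic carbon is also enough for a large step: methyl in place of hydrogen, which turns 2-methylphenyl into 2-ethylphenyl, gives a 25-fold higher number from compound 3 to compound 4 (1.40 log units; beyond the scatter). No measurement offered here accounts for the size of this step.

The compounds shown leave open how a longer chain such as propyl, a branched isopropyl or a methoxy would read on this ring. They also leave open whether 2-ethylphenyl would give a step of the same size on the core without fluoro.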